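Notes on the aryl group: compound 3 to compound 4

The source may hold more compounds than are shown below. What is called first, only, known or untested is meant among the compounds shown, and "the series" means these compounds.

Values in a functional assay on FM3A cells (Mus musculus) for antiproliferative activity; a higher number here means a weaker inhibitor, a lower number a stronger inhibitor
- compound 1 `COc1ccc(-c2cc(N)c(C(=O)c3cc(OC)c(OC)c(OC)c3)s2)cc1OC` gives 72 nM
- compound 2 `COc1cc(C(=O)c2sc(-c3ccc(I)cc3)cc2N)cc(OC)c1OC` gives 420 nM
- compound 3 `COc1cc(C(=O)c2sc(-c3ccccc3)cc2N)cc(OC)c1OC` gives 13 nM

Compound 3 has the lowest number of the three. Compound 4 `COc1cc(C(=O)c2sc(-c3ccc(C)cc3)cc2N)cc(OC)c1OC` carries methyl in place of hydrogen on an aromatic carbon, para to a large group methyl in place of hydrogen on an aromatic carbon and has no measured value yet. Going by the values given here, two measured steps bear on this change. The large 32-fold lower number from compound 2 to compound 3 (1.51 log units; beyond the scatter) concerns iodo at that place, and the modest 5.5-fold lower number from compound 1 to compound 3 (0.74 log units; beyond the scatter) concerns the 3,4-dimethoxyphenyl group. Both compounds with a substituted phenyl sit above compound 3, though neither carries methyl. A modest step to a higher number in this assay is therefore expected, well short of the iodo step. The expected change is a 2.3-fold higher number from compound 3 to compound 4 (0.36 log units; beyond the scatter) as an estimate only. For compound 4 the estimated value is 30 nM with an expected range of 8 nM to 120 nM in this series.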

Compound 4, half-maximal inhibitory concentration: 16 nM
The estimate for compound 4 lay 1.9-fold (0.27 log units) above the measured number, within the range that was stated.
By their numbers in this assay, from the lowest: compounds 3 and 4 (each within the scatter of the next); then compound 1; then compound 2.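

In this assay the 4-methylphenyl group stands level with phenyl, with a 1.2-fold higher number from compound 3 to compound 4 (0.09 log units; within the scatter) as the step, so a group at this place does not by itself raise the number. Iodo and methyl part sharply here, with a 26-fold lower number from compound 2 to compound 4 (1.42 log units; beyond the scatter) on that exchange, so the high number of compound 2 goes with iodo and not with substitution as such. Against the 3,4-dimethoxyphenyl group, 4-methylphenyl stays on the low side as phenyl does, with a 4.5-fold lower number from compound 1 to compound 4 (0.65 log units; beyond the scatter) in that comparison.

As far as these compounds go, whether an amine, a carboxylic acid or a longer chain at this place stays level with methyl or climbs towards iodo remains open. Nothing available accounts for the gap between methyl and iodo.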